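Reversing the amide back on a pyrazole-based ligand

This account rests on a few compounds, and the source may have more. Where it says the series, first, only, none or still open, it means among the compounds named here.

Measured compounds:
- Compound 1, `Cc1cc(C(N)=O)nn1Cc1cc(Cl)cc2cc(-c3ccccc3)oc12`: 5.01 nM
- Compound 2, `Cc1cc(C(=O)NCC2CCNCC2)nn1Cc1cc(Cl)cc2cc(-c3ccccc3)oc12`: 20 nM
- Compound 3, `Cc1cc(NC(=O)CC2CCNCC2)nn1Cc1cc(Cl)cc2cc(-c3ccccc3)oc12`: 63.1 nM

All three share one core and differ only in the group carried on the five-membered aromatic ring. In an assay on CHO-K1 cells for displacement of a labelled ligand from prostaglandin E2 receptor EP1 subtype (Homo sapiens), read by scintillation counting, with a stated time of 45 min (on this read-out lower numbers stand for stronger inhibition and higher numbers for weaker inhibition), compound 3 gives the highest number of the three. The nearest is compound 2, as the step of a 3.2-fold higher number from compound 2 to compound 3 (0.50 log units; beyond the scatter) shows; the furthest is compound 1, by a 13-fold higher number from compound 1 to compound 3 (1.10 log units; beyond the scatter). Both steps lie beyond the usual scatter, so compound 3 is the weakest binder among the three.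

Compound 4, `Cc1cc(C(=O)N[C@H]2CC[C@H](O)CC2)nn1Cc1cc(Cl)cc2cc(-c3ccccc3)oc12`, changes this group: (4-hydroxycyclohexyl)carbamoyl in place of (((piperidin-4-yl)methyl)carbonyl)amino on an aromatic carbon. Among the measured compounds shown here, two measured steps bear on it. The step of a 3.2-fold higher number from compound 2 to compound 3 (0.50 log units; beyond the scatter) shows what moving from a carbamoyl arrangement to the reversed arrangement cost; going back the other way, as in compound 4, would be expected to recover roughly that amount. The step of a 4.0-fold higher number from compound 1 to compound 2 (0.60 log units; beyond the scatter) shows that a substituent on the amide nitrogen raised the number in this assay, so compound 4 is not expected to reach compound 1. For the measured compounds named here, no measured pair tells how the hydroxycyclohexyl ring compares with the piperidinylmethyl chain. For compound 4 a modestly lower number is therefore expected, a 3.5-fold lower number from compound 3 to compound 4 (0.54 log units; beyond the scatter), giving an estimate of 18 nM with a range from 6 nM to 55 nM.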

Compound 4, half-maximal inhibitory concentration: 7.94 nM
Beside the measured number, compound 4's estimate is 2.3-fold (0.36 log units) above it; measured number inside the range.
By their numbers in this assay, from the lowest: compounds 1 and 4 (each within the scatter of the next); then compound 2; then compound 3.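

In this assay, the new group on the aromatic carbon gives a 7.9-fold lower number from compound 3 to compound 4 (0.90 log units; beyond the scatter), but this step changes both the direction of the amide and the ring, so it cannot assign the gain to either one alone. The cleaner comparison keeps the carbamoyl arrangement and alters only the group on the amide nitrogen: 4-hydroxycyclohexyl in place of (piperidin-4-yl)methyl gives a 2.5-fold lower number from compound 2 to compound 4 (0.40 log units; beyond the scatter), the first sign that the identity of this group matters, and not merely whether one is present. Set against the bare amide, the same group gives a 1.6-fold higher number from compound 1 to compound 4 (0.20 log units; within the scatter), so a substituent on this nitrogen need not raise the number, although compound 2 shows that one can.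

Nothing available here explains these steps. Going by these compounds, it remains open whether the hydroxyl or the carbon ring accounts for the result, which a plain cyclohexyl or a 4-aminocyclohexyl on the amide nitrogen could test, while the reversed amide carrying a 4-hydroxycyclohexyl group could separate the direction of the amide from the choice of ring.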